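This account rests on a few compounds, and the source may have more. Where it says the series, first, only, none or still open, it means among the compounds named here.

Measured compounds in an in vitro assay on BTI-TN-5B1-4 cells for inhibition of Amine oxidase [flavin-containing] A (Homo sapiens), tested at 100 uM; on this read-out lower numbers stand for less inhibition and higher numbers for more inhibition at the one concentration tested (going by the name of the read-out):
compound 1, `COc1ccc(-c2cc(=S)c3ccc(OC)cc3o2)cc1`, gives "not active" (no number reported).
compound 2, `COc1ccc(-c2cc(=S)c3ccc(F)cc3o2)cc1`, gives "not active" (no number reported).
compound 3, `COc1ccc(-c2cc(=S)c3ccccc3o2)cc1`, gives 40%.

Within the data shown here, compound 1 stands without a single number in this assay; the same holds for compound 2, so only compound 3 carries a figure within the set, and no pair of measured compounds differing in one place is available. Compound 4, `COc1ccc2c(=S)cc(-c3ccccc3)oc2c1`, has not been measured in this assay. It differs from compound 1 by hydrogen in place of methoxy on an aromatic carbon. Among the measured compounds shown here, with no measured step of this kind, the size of the change in this assay from compound 1 to compound 4 cannot be read from the data; compound 1 is reported as not active, so some rise in the number is possible, but nothing beyond the scatter is required. Compound 4 is expected to give about 15%, in an estimated range from 0% to 45%, with a fair chance that no number is reported.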

Compound 4, a percentage reported as inhibition, at one concentration (the size of the read-out at that concentration, not a potency): "not active" (no number reported)
For compound 4 the study gives words and no number; there is nothing to compare the estimate with.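

In this assay compound 1 and compound 4 carry no number, so no step can be read between them. Left open is how the figure of compound 3, 40% in this assay, relates to the compounds without a number. No measured evidence bears on this result.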